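Changing the Sulfonamide Group on Compound 1

The compounds below may be only part of what the source reports. "The series", "measured", "known", "first", "only" and "open" are said of these compounds alone.

Of the compounds shown here, two with a shared core have been measured so far. In a functional assay on MCF7 cells (Homo sapiens) for antiproliferative activity, read by sulforhodamine B assay, with a stated time of 48 h (a lower number here means a stronger inhibitor, a higher number a weaker inhibitor), compound 1 (`CCc1ccccc1NS(=O)(=O)c1ccc(N2CCNC2=O)cc1`) gives 350 nM and compound 2 (`O=C1NCCN1c1ccc(S(=O)(=O)Nc2ccc3[nH]ccc3c2)cc1`) gives 170 nM in the same test. Compound 1 therefore has the higher number of the pair and is the weaker inhibitor, though the gap only just clears the normal scatter of repeat measurements.

Compound 3 (`O=C1NCCN1c1ccc(S(=O)(=O)Nc2ccc(F)c(F)c2)cc1`) has not been measured yet. It keeps the core of compound 1 and differs in one place, on a sulfonamide nitrogen: 3,4-difluorophenyl in place of 2-ethylphenyl on a sulfonamide nitrogen (3,4-difluorophenyl in place of 2-ethylphenyl).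

Within the data shown here, no measured pair yet shows the size of a comparable step, so any forecast is loose. Among the measured compounds shown here, the only guide is the narrow gap between compound 1 at 350 nM and compound 2 at 170 nM in this assay and it suggests a step of modest size. The expected change is a 2.3-fold higher number from compound 1 to compound 3 (0.36 log units; beyond the scatter) in this assay which would be a move toward weaker inhibition, near the edge of the scatter. For compound 3 the estimate is 800 nM with 200 nM as the expected lower end and 3000 nM as the expected upper end of the range.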

Compound 3, half-maximal inhibitory concentration: 620 nM
Compound 3: middle estimate off by 1.3-fold (0.11 log units), on the high side; low and high end bracket the measured number.
By their numbers in this assay, from the lowest: compound 2; then compounds 1 and 3 (each within the scatter of the next).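

In this assay the exchange on the sulfonamide nitrogen gives a 1.8-fold higher number from compound 1 to compound 3 (0.25 log units; within the scatter) and so leaves the two compounds indistinguishable in this test. Among these compounds, this is the first measured step at this position, and it shows that 3,4-difluorophenyl can stand in place of 2-ethylphenyl without a change that rises above the ordinary variation between repeat measurements, even though the two groups carry different atoms on a six-membered aromatic ring of carbon only. No independent measurement bears on this result, so the data offer no explanation for it.

One step cannot show how far this tolerance extends, as both groups are substituted phenyl rings of 8 heavy atoms; a plain phenyl, a phenyl with a single fluorine, or a cyclohexyl ring on the same nitrogen would help to separate the role of the ring from that of its substituents. As far as these compounds go, it also remains open whether a longer alkyl chain, an amine or a carboxylic acid at this place would keep the antiproliferative activity of compound 1 or compound 3.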